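A few compounds are considered here, and "the series" means these few. Any claim that something is new, unique, unknown or untested is made for them only; others in the source may bear on it.

Working notes on the series. The shared core carries an anilino-pyrimidine arm whose terminal aryl ring is the point of variation. Compound 1 `Cn1cc(/C=C2/C(=O)Nc3ccccc32)c2cc(Nc3nccc(-c4ccccc4)n3)ccc21` carries a plain phenyl there and in a functional assay on U-87MG ATCC cells (Homo sapiens) for cytotoxicity, read by MTT assay, with a stated time of 48 h (a higher number here means a weaker inhibitor, a lower number a stronger inhibitor), compound 1 gives 14100 nM. Compound 2 `Cn1cc(/C=C2/C(=O)Nc3ccccc32)c2cc(Nc3nccc(-c4ccc(C(F)(F)F)cc4)n3)ccc21` carries a 4-(trifluoromethyl)phenyl instead, and in this assay compound 2 gives 26000 nM. For the measured compounds named here, of the two numbers so far, compound 2 and compound 1 are not separated beyond the scatter: the step of a 1.8-fold higher number from compound 1 to compound 2 (0.27 log units; within the scatter), trifluoromethyl in place of hydrogen on an aromatic carbon, falls within it.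

Compound 3 `Cn1cc(/C=C2/C(=O)Nc3ccccc32)c2cc(Nc3nccc(-c4cccnc4)n3)ccc21` changes the same terminal ring: pyridin-3-yl in place of 4-(trifluoromethyl)phenyl on an aromatic carbon. Going by the values given here, the single measured step, from compound 1 to compound 2, is the only one that touches this ring, and it did not move the number beyond the scatter. Among the compounds with values here, nothing among the measured compounds shows a ring nitrogen at this position, so the expectation rests on the weak response seen so far. The expected step of a 1.5-fold lower number from compound 2 to compound 3 (0.18 log units; within the scatter) is therefore small, with no direction beyond the scatter. Compound 3 is estimated at 17000 nM in this assay, within 6500 nM to 45000 nM.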

Compound 3, half-maximal inhibitory concentration: 14800 nM
Compound 3: middle estimate off by 1.1-fold (0.06 log units), on the high side; measured number inside the range.
By their numbers in this assay, from the lowest: compounds 1, 3 and 2 (each within the scatter of the next).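

In this assay, for the compounds shown here, the ring nitrogen of pyridin-3-yl brings a hetero atom and a hydrogen-bond acceptor to this position for the first time, and neither comparison leaves the scatter (a 1.8-fold lower number from compound 2 to compound 3 (0.24 log units; within the scatter); a 1.0-fold higher number from compound 1 to compound 3 (0.02 log units; within the scatter)). The change from 4-(trifluoromethyl)phenyl also removes four heavy atoms and all three fluorine atoms, yet compound 2 and compound 3 remain unseparated. Across compound 1, compound 2 and compound 3, then, replacing the carbon-only terminal ring with a pyridin-3-yl ring or adding trifluoromethyl gives no step beyond the scatter, and no outside data on these compounds bear on this result.

The compounds shown leave open whether a terminal group of a different kind, such as a morpholine, a carboxylic acid or an aminoalkyl chain, would give a step beyond the scatter at this position. They also leave open whether the pyridine nitrogen placed elsewhere in the terminal ring, as in pyridin-2-yl or pyridin-4-yl, would give the same result.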